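Methyl on the piperazine nitrogen of compound 1

The source may hold more compounds than are shown below. What is called first, only, known or untested is meant among the compounds shown, and "the series" means these compounds.

Of the compounds shown here, two have been measured in an assay on HeLa cells for displacement of a labelled ligand from 5-hydroxytryptamine receptor 6 (Homo sapiens); on this read-out lower numbers stand for stronger inhibition and higher numbers for weaker inhibition. Compound 1 `O=S(=O)(c1cccc2ccccc12)c1cccc2oc(N3CCNCC3)nc12` gives 3.1 nM, the lowest of the two numbers. For the measured compounds named here, compound 2 `O=S(=O)(c1ccc2oc(N3CCNCC3)nc2c1)c1cccc2ccccc12` gives 52 nM in this assay; the gap between the two numbers lies beyond the scatter, and no single structural step connects the two compounds, so the comparison says only that the sulfonyl arrangement of compound 1 is the one with the lower number.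

Compound 3 `CN1CCN(c2nc3c(S(=O)(=O)c4cccc5ccccc45)cccc3o2)CC1` has not been measured in this assay. It differs from compound 1 by methyl in place of hydrogen on an amine nitrogen in a ring. Going by the values given here, no measured pair carries this change, so its size is open. Since the rest of the molecule is unchanged, a small step is expected, most likely toward a slightly higher number, though a step within the scatter would not be surprising. For compound 3 the estimate in this assay is 5 nM, with a range from 1.5 nM to 15 nM. This estimate corresponds to the expected step of a 1.6-fold higher number from compound 1 to compound 3 (0.21 log units; within the scatter).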

Compound 3, inhibition constant: 9.7 nM
Estimate against measurement, compound 3: 1.9-fold (0.29 log units) below; low and high end bracket the measured number.
By their numbers in this assay, from the lowest: compound 1; then compound 3; then compound 2.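

For the compounds shown here, on this assay the change from piperazin-1-yl to 4-methylpiperazin-1-yl gives a 3.1-fold higher number from compound 1 to compound 3 (0.50 log units; beyond the scatter) and is the first step that differs in one place only. It is a modest step, but it lies beyond the scatter, so the amine nitrogen in the ring is a position where even one added carbon moves the number, while compound 3 at 9.7 nM shows that inhibition on this read-out survives the methyl. Nothing at hand explains the size or direction of this step.

The compounds shown leave open whether the trend continues with a longer chain on this nitrogen, such as ethyl or propyl, and how a hydroxyethyl chain or an acetyl group would compare with methyl and with hydrogen. Also open, on these data alone, is whether the same methyl step holds on the sulfonyl arrangement of compound 2, since a single step on the core of compound 1 cannot say whether the change behaves alike on another arrangement.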